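The source may report more compounds than this note shows. Statements on the series, on what has been measured and on what is new or still open speak of the compounds shown alone.

Measured in an ADME assay (Homo sapiens) for solubility; a lower number here means a less soluble compound, a higher number a more soluble compound:
- compound 1 `CC[C@@H](NC(=O)c1ccc(Cl)s1)C(=O)Nc1ccc(N2CCOCC2=O)c(C)c1`: 41 ug/mL
- compound 2 `Cc1cc(NC(=O)[C@@H](C)NC(=O)c2ccc(Cl)s2)ccc1N1CCOCC1=O`: 134 ug/mL

Of these two compounds, compound 2 has the higher number, at 134 ug/mL. The next compound to be tested is compound 3 `CCCOC[C@@H](NC(=O)c1ccc(Cl)s1)C(=O)Nc1ccc(N2CCOCC2=O)c(C)c1`. It keeps the core of compound 2 and changes one site: propoxy in place of hydrogen on a saturated chain carbon, two bonds along the chain from an amide-type nitrogen and a carbonyl carbon. In words, this is propoxy in place of hydrogen on a saturated chain carbon, two bonds along the chain from an amide-type nitrogen and a carbonyl carbon.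

Among the measured compounds shown here, only one measured step bears on this change. It sits at the same place and puts hydrogen in place of methyl: a 3.3-fold higher number from compound 1 to compound 2 (0.51 log units; beyond the scatter). That step is modest but beyond the scatter. Compound 3 goes the opposite way, adding to that carbon, and it adds more than the methyl of compound 1. A lower number in this assay is therefore expected, probably by more than that one step. For the measured compounds named here, no measured compound carries propoxy, so the size stays uncertain.

The estimated change is a 6.7-fold lower number from compound 2 to compound 3 (0.83 log units; beyond the scatter). For compound 3 the expected value is 20 ug/mL, with an estimated range from 5 ug/mL to 70 ug/mL.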

Compound 3, solubility: 92 ug/mL
For compound 3 the middle estimate is 4.6-fold (0.66 log units) below the measured one, and the stated range ends below it.
By their numbers in this assay, from the lowest: compound 1; then compounds 3 and 2 (each within the scatter of the next).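

In this assay, propoxy in place of hydrogen on this saturated chain carbon gives a 1.5-fold lower number from compound 2 to compound 3 (0.16 log units; within the scatter), so this position accepts a much larger group than hydrogen with no change that stands out from the scatter. Propoxy in place of methyl at the same carbon gives a 2.2-fold higher number from compound 1 to compound 3 (0.35 log units; beyond the scatter), which shows that the two substituted compounds do not behave alike. Compounds 1 and 2 alone could be read as a simple rule that more substitution on this carbon gives a lower number, but compound 3 goes against that rule, since it carries the larger group and still has a higher number than compound 1. Nothing measured here gives a reason for this result.

The compounds shown cannot separate the part played by the oxygen in propoxy from that of the chain, and a plain butyl group at this carbon would bear directly on that question. From the compounds shown here alone, whether the same tolerance holds for an amine or a carboxylic acid at this carbon also remains open.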